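The compounds below may be only part of what the source reports. "The series", "measured", "known", "first", "only" and "open" are said of these compounds alone.

Measured so far:
compound 1 `Cc1cc(=O)c2c(O)c(CN3CCC(Cc4ccccc4)CC3)c(O)c([C@H]3CCN(C)C[C@H]3O)c2o1`: 18%
compound 2 `Cc1oc2c([C@H]3CCN(C)C[C@H]3O)c(O)cc(O)c2c(=O)c1C(O)c1ccc(Cl)cc1`: 15%

In a functional assay on MIA PaCa-2 cells (Homo sapiens) for inhibition, read by MTT assay, with a stated time of 48 h, tested at 10 uM (on this read-out lower numbers stand for less inhibition of growth and higher numbers for more inhibition of growth at the one concentration tested), compound 2 gives 15%, the lower of the two numbers shown, while compound 1 gives 18%; the gap between them lies within the scatter, so the two cannot be told apart. Compound 3 `Cc1oc2c([C@H]3CCN(C)C[C@H]3O)c(O)cc(O)c2c(=O)c1C(O)c1csc([N+](=O)[O-])c1` differs from compound 2 in one place: 5-nitrothiophen-3-yl in place of 4-chlorophenyl on a saturated chain carbon bound to an aromatic carbon and an oxygen on a saturated carbon. Going by the values given here, no measured pair shows what such a change does here, so its direction is unknown. Both measured compounds show little growth inhibition at this concentration, and compound 3 is expected to stay in that range, with a step of a number 3 percentage points higher from compound 2 to compound 3 (within the scatter) of no size beyond the scatter. Compound 3 is therefore estimated at 18%, between 5% and 35%.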

Compound 3, percent growth inhibition at one concentration: 41%
Beside the measured number, compound 3's estimate is 23 percentage points below it; measured number outside the range, above it.
By their numbers in this assay, from the lowest: compounds 2 and 1 (each within the scatter of the next); then compound 3.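

In this assay, placing 5-nitrothiophen-3-yl instead of 4-chlorophenyl on this saturated chain carbon gives a number 26 percentage points higher from compound 2 to compound 3 (beyond the scatter). This shows that growth inhibition at this concentration responds to the aromatic group held at this position. No evidence here explains the step.

The nitro group and the thiophene ring enter together, and the compounds shown do not separate their contributions. A plain thiophene ring or a nitrophenyl group at the same carbon would be needed to tell them apart.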